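The source may hold more compounds than are shown below. What is called first, only, known or untested is meant among the compounds shown, and "the series" means these compounds.

In a functional assay on ECa-109 cells for inhibition, with ECa-109 cell line (Homo sapiens) as the target, read by sulforhodamine B assay (a higher number here means a weaker inhibitor, a lower number a stronger inhibitor), two compounds on the shared core have been read so far. Compound 1 (`O=C1C(NC2CCCC2)=CC(=O)c2c1nc1n2[C@H]2OC[C@@H](O)[C@H]2OC1`) with cyclopentyl on the amine nitrogen gives > 16000 nM as a limit of the assay and not a number. For the measured compounds named here, compound 2 (`CCOc1ccccc1NC1=CC(=O)c2c(nc3n2[C@H]2OC[C@@H](O)[C@H]2OC3)C1=O`) with 2-ethoxyphenyl in that place gives 4320 nM as the only true number so far. Going by the values given here, the one measured step is an at least 3.7-fold lower number from compound 1 to compound 2 (0.56 log units; beyond the scatter) and it lies beyond the scatter. Compound 3 (`O=C1C(Nc2cccc(Cl)c2)=CC(=O)c2c1nc1n2[C@H]2OC[C@@H](O)[C@H]2OC1`) changes the group again (3-chlorophenyl in place of 2-ethoxyphenyl on an amine nitrogen), with 3-chlorophenyl in place of 2-ethoxyphenyl on the amine nitrogen. The step of an at least 3.7-fold lower number from compound 1 to compound 2 (0.56 log units; beyond the scatter) removed cyclopentyl and so gives no size for an exchange of one substituted phenyl for another, and no step beyond the scatter is expected in this assay here. The estimated change is small (a 1.2-fold lower number from compound 2 to compound 3 (0.09 log units; within the scatter)) and within the scatter. Compound 3 is expected at 3500 nM within a range of 1000 nM to 14000 nM in this estimate.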

Compound 3, half-maximal inhibitory concentration: 3080 nM
Estimate against measurement, compound 3: 1.1-fold (0.06 log units) above, within the range that was stated.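

In this assay the exchange of one substituted phenyl for another on the amine nitrogen stays within the scatter, with a 1.4-fold lower number from compound 2 to compound 3 (0.15 log units; within the scatter), even though the hydrogen-bond acceptor of 2-ethoxyphenyl is absent from 3-chlorophenyl. A second substituted phenyl also separates from cyclopentyl, with an at least 5.1-fold lower number from compound 1 to compound 3 (0.71 log units; beyond the scatter), so the lower number seen earlier is not tied to 2-ethoxyphenyl alone. Compound 1 is a limit of the assay and not a number, so the full size of that step stays unknown: the limit of > 16000 nM in this assay, at which 1 of the 3 values shown sits.

The compounds shown leave open whether an unsubstituted phenyl, a benzyl or a pyridine on the amine nitrogen would read like compound 2 and compound 3. Cyclopentyl is also the only group without an aromatic ring here, so one example cannot show how an open alkyl chain would read.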